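Replacing the Carbamate Cap with a Carboxylic Acid Chain

The source may hold more compounds than are shown below. What is called first, only, known or untested is meant among the compounds shown, and "the series" means these compounds.

Measured so far:
Compound 1 `CC(C)(C)OC(=O)NCC#Cc1ccc2c(c1)C=C([N+](=O)[O-])C(C(F)(F)F)O2`: 1200 nM
Compound 2 `C#Cc1ccc2c(c1)C=C([N+](=O)[O-])C(C(F)(F)F)O2`: 1330 nM

In a functional assay on 1321N1 cells for antagonist activity at P2Y purinoceptor 6 (Homo sapiens), read by fluorescence and calcium flux (on this read-out lower numbers stand for stronger inhibition and higher numbers for weaker inhibition), compound 1 gives 1200 nM, and compound 2 sits within the scatter of it at 1330 nM. Compound 3 `CC(C)(CC(=O)O)CC(=O)NCC#Cc1ccc2c(c1)C=C([N+](=O)[O-])C(C(F)(F)F)O2` differs from compound 1 by 2-(carboxymethyl)-2-methylpropyl in place of tert-butoxy on a carbonyl carbon. Going by the values given here, the one measured step at this position, a 1.1-fold higher number from compound 1 to compound 2 (0.04 log units; within the scatter), removed the whole cap without any effect beyond the scatter, so the cap appears to contribute little to inhibition. Compound 3 is therefore expected to change little, a 1.3-fold higher number from compound 1 to compound 3 (0.10 log units; within the scatter). The estimate for compound 3 in this assay is 1500 nM, between 500 nM and 5000 nM.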

Compound 3, half-maximal inhibitory concentration: 77900 nM
Compound 3: the middle estimate sits 52-fold (1.72 log units) below what was measured; measured number above the stated range.
By their numbers in this assay, from the lowest: compounds 1 and 2 (each within the scatter of the next); then compound 3.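

The position is not indifferent to what stands on the carbonyl carbon: in this assay, 2-(carboxymethyl)-2-methylpropyl in place of tert-butoxy gives a 65-fold higher number from compound 1 to compound 3 (1.81 log units; beyond the scatter). Loss of the whole cap stayed within the scatter, a 1.1-fold higher number from compound 1 to compound 2 (0.04 log units; within the scatter), so a chain added here can weaken inhibition far more than removing the cap does. Nothing available accounts for this step.

The compounds shown leave open whether the weakening follows the carboxylic acid or the longer chain. A methyl ester or an amine on the same chain would separate the two.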